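A few compounds are considered here, and "the series" means these few. Any claim that something is new, unique, unknown or untested is made for them only; others in the source may bear on it.

Measured in a functional assay on MT2 cells (Homo sapiens) for antiproliferative activity, read by MTT assay, with a stated time of 72 h; a lower number here means a stronger inhibitor of growth, a higher number a weaker inhibitor of growth:
- compound 1 `O=C(COc1ccc2c(=O)c(-c3ccccc3)coc2c1)Nc1ccc2ccccc2c1`: 7680 nM
- compound 2 `O=C(COc1c(-c2ccccc2)oc2ccccc2c1=O)Nc1ccccc1`: 6720 nM

Compound 2, at 6720 nM, stands level with compound 1, at 7680 nM. The gap between these two numbers lies within the usual scatter of repeated measurements, so they cannot be ranked. The two structures also differ in more than one place, which means that no single change can be read from this pair.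

The next compound to be measured is compound 3 `COc1ccc(NC(=O)COc2c(-c3ccccc3)oc3ccccc3c2=O)cc1`. It is compound 2 with one change: methoxy in place of hydrogen on an aromatic carbon. In words, methoxy takes the place of hydrogen on an aromatic carbon, para to a large group, turning phenyl into 4-methoxyphenyl.

Going by the values given here, no measured pair shows what this change does. The starting point is therefore compound 2 at 6720 nM, and no step beyond the scatter is expected in this assay, in either direction. The expected result is an estimated 1.1-fold lower number from compound 2 to compound 3 (0.05 log units; within the scatter). For compound 3 the estimated value is 6000 nM, with an expected range from 2500 nM to 13000 nM.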

Compound 3, concentration for 50% growth inhibition: > 10000 nM
Compound 3 gave a limit, no number (the forecaster's own chance of this, stated with the estimate: 5%); middle value at least 1.6-fold (0.22 log units) from the limit.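

In this assay compound 3 gives > 10000 nM, which is a limit of the assay and not a number. Going by these compounds alone, this is the first reading of any change on this ring, and it reads an at least 1.4-fold higher number from compound 2 to compound 3 (0.17 log units; that floor lies within the scatter), so turning phenyl into 4-methoxyphenyl, with methoxy para to a large group, brings no stronger inhibition of growth, though that floor alone does not establish a real loss. The true size of the step stays unknown, and the result can be taken only as a lower bound on the number for compound 3: the limit of > 10000 nM in this assay, at which 1 of the 3 values shown sits.

As far as these compounds go, whether a hydroxyl group, an amine or a carboxylic acid in this same place would give a lower number remains open, as does the effect of methoxy at another carbon of this ring. Also open, from the compounds shown here alone, is whether the same change would give a similar result on the core of compound 1, where a different group stands on the amide nitrogen.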